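Chloro on the pyridine ring and cytotoxicity in BV-2 cells

This account rests on a few compounds, and the source may have more. Where it says the series, first, only, none or still open, it means among the compounds named here.

Measured so far:
compound 1, `COc1ccccc1S(=O)(=O)/C=C/c1ccccn1`: 100%
compound 2, `COc1ccccc1S(=O)(=O)/C=C/c1ccc(Cl)cn1`: 100%
compound 3, `COc1cccc(S(=O)(=O)/C=C/c2cccnc2)c1`: 100%

All three compounds were examined in an ADME assay on BV-2 cells (Mus musculus) for cytotoxicity, with a stated time of 24 h, tested at 10 uM; a higher number here means a weaker effect of the compound at the concentration tested, a lower number a stronger effect. Compound 1 gives 100% in this assay, and compound 2, which carries the change (chloro in place of hydrogen on an aromatic carbon), gives 100%. The step of no change at the digits printed from compound 1 to compound 2 (within the scatter) is therefore flat. Compound 3 has the same atoms as compound 1 joined differently; the difference between the two cores is not broken down here. In this assay compound 3 gives 100%, so the three measured values sit together at the top of the scale.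

Compound 4, `COc1cccc(S(=O)(=O)/C=C/c2cccnc2Cl)c1`, has not yet been measured. It arises from compound 3 by chloro in place of hydrogen on an aromatic carbon. Among the measured compounds shown here, this is the same kind of change as the one from compound 1 to compound 2, but the surroundings differ: in compound 2 the chloro sits two atoms from the ring nitrogen and para to a large group, whereas in compound 4 it sits next to the ring nitrogen and ortho to a large group.

For the measured compounds named here, since the only measured example of this kind of change, no change at the digits printed from compound 1 to compound 2 (within the scatter), moved nothing, the step from compound 3 to compound 4 in this assay is expected to be no change at the digits printed from compound 3 to compound 4 (within the scatter). Compound 4 is accordingly estimated at 100%, with a likely range from 88% to 100%.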

Compound 4, a percentage reported as activity, at one concentration (the size of the read-out at that concentration, not a potency): 100%
Compound 4: the middle estimate sits on the measured number at the digits printed, within the range that was stated.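

Carried to a second core, chloro in place of hydrogen on an aromatic carbon behaves in this assay as it did on the first, with no change at the digits printed from compound 3 to compound 4 (within the scatter), and the two steps agree: the same change on two cores in this assay, no change at the digits printed (within the scatter) from compound 1 to compound 2 and no change at the digits printed (within the scatter) from compound 3 to compound 4, 0 percentage points apart, within the scatter of two such steps. Within these two pairs the change therefore carries over from one core to the other, even though in compound 4 the chloro stands next to the ring nitrogen and ortho to a large group. Among the compounds shown here, all four compounds sit at the top of the scale, however, so the flat steps show only that neither pair departs from that level at the single concentration tested; they do not show that the change would stay silent on a core reading lower in this assay, and they say nothing about potency or about any other read-out.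

What the compounds shown leave open is how other groups would read on the same aromatic carbon, such as bromo, an amine or a carboxylic acid. Also open, as far as these compounds go, is whether a longer chain in place of the methoxy group would move the value away from the top of the scale.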